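Compound 2 to compound 4: hydrogen in place of methyl

The source may report more compounds than this note shows. Statements on the series, on what has been measured and on what is new or still open speak of the compounds shown alone.

Measured compounds in a functional assay on ileum (Cavia porcellus) for inhibition; a higher number here means a weaker inhibitor, a lower number a stronger inhibitor
- compound 1 `COC(=O)C1=C(C)NC(C)=C(C(=O)OC)C1c1c(-c2cccs2)nc2sccn12` gives 110 nM
- compound 2 `COC(=O)C1=C(C)NC(C)=C(C(=O)OC)C1c1c(-c2ccsc2)nc2sc(C)cn12` gives 3520 nM
- compound 3 `COC(=O)C1=C(C)NC(C)=C(C(=O)OC)C1c1c(-c2ccncc2)nc2sc(C)cn12` gives 9690 nM

Compound 2 holds the second highest of the three numbers, with compound 3 higher and compound 1 much lower. Compound 4 `COC(=O)C1=C(C)NC(C)=C(C(=O)OC)C1c1c(-c2ccsc2)nc2sccn12` has hydrogen in place of methyl on an aromatic carbon. Among the measured compounds shown here, no measured step isolates this change. For the measured compounds named here, the only measured step (a 2.8-fold higher number from compound 2 to compound 3 (0.44 log units; beyond the scatter)) puts pyridin-4-yl in place of thiophen-3-yl, so it offers no more than a rough scale for one change. Compound 1 (110 nM) also has hydrogen at this place, but it differs from compound 2 in a second place as well, so the data cannot separate the two changes. On that limited evidence, a lower number is expected in this assay for compound 4, without the full gap to compound 1 being reached. The expected change is a 5.9-fold lower number from compound 2 to compound 4 (0.77 log units; beyond the scatter) according to this estimate. Compound 4 is estimated at 600 nM with an expected range from 150 nM to 2500 nM for a single measurement.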

Compound 4, half-maximal inhibitory concentration: 2.3 nM
The estimate for compound 4 lay 260-fold (2.42 log units) above the measured number; measured number below the stated range.
By their numbers in this assay, from the lowest: compound 4; then compound 1; then compound 2; then compound 3.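

In this assay, among the compounds shown here, the methyl on the aromatic carbon next to the ring sulfur proves decisive: hydrogen in its place gives a 1500-fold lower number from compound 2 to compound 4 (3.18 log units; beyond the scatter), far larger than the only earlier single-place step, a 2.8-fold higher number from compound 2 to compound 3 (0.44 log units; beyond the scatter). With hydrogen at this carbon, the choice of thiophene attachment also counts strongly, as thiophen-3-yl in place of thiophen-2-yl gives a 48-fold lower number from compound 1 to compound 4 (1.68 log units; beyond the scatter). Nothing at hand bears on why either step is so large.

For the compounds shown here, still open is whether the methyl step carries over to the thiophen-2-yl and pyridin-4-yl compounds, since each appears here with only one of the two groups at this carbon. Also open, as far as these compounds go, is how an ethyl group, a chlorine atom or an aminomethyl group at this carbon would read in this assay.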